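Replacing the 2-chlorophenyl group of compound 2

The source may hold more compounds than are shown below. What is called first, only, known or untested is meant among the compounds shown, and "the series" means these compounds.

Compound 1 `CCN(CC)C(=S)SC(CC(=O)c1ccccc1)c1ccc(Br)cc1`: 80 nM
Compound 2 `CCN(CC)C(=S)SC(CC(=O)c1ccccc1)c1ccccc1Cl`: 4500 nM

In a functional assay on MCF7 cells (Homo sapiens) for cytotoxicity, read by MTT assay, with a stated time of 48 h (on this read-out higher numbers stand for weaker inhibition and lower numbers for stronger inhibition), compound 2 stands highest of the two measured compounds, at 4500 nM. Compound 3 `CCN(CC)C(=S)SC(CC(=O)c1ccccc1)c1cccc([N+](=O)[O-])c1` has 3-nitrophenyl in place of 2-chlorophenyl on the same saturated chain carbon: 3-nitrophenyl in place of 2-chlorophenyl on a saturated chain carbon bound to a saturated chain carbon and a sulfur. For the measured compounds named here, one measured step bears on this change: a 56-fold higher number from compound 1 to compound 2 (1.75 log units; beyond the scatter), which is large and beyond the scatter. Going by the values given here, no compound with a 3-nitrophenyl group has been measured, so this step shows only how far a change at this place can move the number. A smaller step towards a lower number in this assay is expected. The expected step is a 5.6-fold lower number from compound 2 to compound 3 (0.75 log units; beyond the scatter). For compound 3 the estimate is 800 nM, with an expected range of 120 nM to 5000 nM.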

Compound 3, half-maximal inhibitory concentration: 9000 nM
Estimate against measurement, compound 3: 11-fold (1.05 log units) below, and the stated range ends below it.
By their numbers in this assay, from the lowest: compound 1; then compounds 2 and 3 (each within the scatter of the next).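

In this assay the exchange of 2-chlorophenyl for 3-nitrophenyl gives a 2.0-fold higher number from compound 2 to compound 3 (0.30 log units; within the scatter) and so does not separate these two groups at this saturated chain carbon. The exchange of 4-bromophenyl for 3-nitrophenyl gives a 110-fold higher number from compound 1 to compound 3 (2.05 log units; beyond the scatter) and so leaves compound 1 alone on the low side, now against two different groups. Nothing measured on these compounds accounts for this gap.

Open, on these data alone, is whether a 4-chlorophenyl or a 2-bromophenyl group at this carbon would fall with compound 1 or with compound 2 and compound 3. An unsubstituted phenyl group would give the series its missing reference point.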